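Swapping an Isopropyl Aryl Ether for a Halogenated One

The source may hold more compounds than are shown below. What is called first, only, known or untested is meant among the compounds shown, and "the series" means these compounds.

Of the compounds shown here, three sharing one core have been measured in an in vitro ADME assay on microsomes from liver (Homo sapiens) for metabolic stability, tested at 1 uM; on this read-out higher numbers stand for fast clearance and lower numbers for slow clearance. Compound 1 `Cn1c(CN2C[C@@H]3C(COc4ccccc4)[C@@H]3C2)nc2ccccc21` gives 14.2 mL/min/kg. Compound 2 `Cn1c(CN2C[C@@H]3C(COc4cccc(-c5ccccc5)c4)[C@@H]3C2)nc2ccccc21`, which carries phenyl in place of hydrogen on an aromatic carbon, gives 11 mL/min/kg, a step of a 1.3-fold lower number from compound 1 to compound 2 (0.11 log units; within the scatter). Compound 3 `CC(C)c1ccc(OCC2[C@H]3CN(Cc4nc5ccccc5n4C)C[C@@H]23)cc1`, with isopropyl in place of hydrogen on an aromatic carbon, gives 5.8 mL/min/kg and so has the lowest of the three numbers; its step from compound 1 is a 2.4-fold lower number from compound 1 to compound 3 (0.39 log units; beyond the scatter), while its gap to compound 2 lies within the scatter, so no order between compounds 2 and 3 can be claimed.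

Compound 4 `Cn1c(CN2C[C@@H]3C(COc4ccc(Cl)cc4F)[C@@H]3C2)nc2ccccc21` has not yet been measured in this assay. It differs from compound 3 in one place: 4-chloro-2-fluorophenyl in place of 4-isopropylphenyl on an oxygen on a saturated carbon. Going by the values given here, no measured step covers this exact exchange. The two steps that bear on it, a 2.4-fold lower number from compound 1 to compound 3 (0.39 log units; beyond the scatter) and a 1.3-fold lower number from compound 1 to compound 2 (0.11 log units; within the scatter), show that changing the group on the phenyl ring moved the number by a modest amount at most, and in one case not beyond the scatter. The number for compound 4 is therefore estimated at 9.5 mL/min/kg, within a range from 5 mL/min/kg to 18 mL/min/kg. This estimate corresponds to an expected step of a 1.6-fold higher number from compound 3 to compound 4 (0.21 log units; within the scatter), which is within the scatter.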

Compound 4, clearance: 6.9 mL/min/kg
For compound 4 the middle estimate is 1.4-fold (0.14 log units) above the measured one, within the range that was stated.
By their numbers in this assay, from the lowest: compounds 3, 4, 2 and 1 (each within the scatter of the next, the first and the last beyond it).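

In this assay, the exchange of 4-isopropylphenyl for 4-chloro-2-fluorophenyl on the oxygen gives a 1.2-fold higher number from compound 3 to compound 4 (0.08 log units; within the scatter), so on this read-out a group made of carbon alone and a halogen-bearing ring cannot be told apart at this position. Set against the plain phenyl, the new group gives a 2.1-fold lower number from compound 1 to compound 4 (0.31 log units; beyond the scatter), which makes it the second group after 4-isopropylphenyl whose step from the plain phenyl lies beyond the scatter, so such a step does not depend on the isopropyl group; compound 2 goes against this pattern, with a 1.3-fold lower number from compound 1 to compound 2 (0.11 log units; within the scatter). No measurement at hand offers an explanation for these numbers.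

On these data alone, the chlorine and the fluorine entered together, so what each does alone stays open, and a ring carrying only 4-chloro or only 2-fluoro would be needed to separate them. As far as these compounds go, it is also open whether an amine, a carboxylic acid or a methoxy group on this ring would keep the number in the same region or move it well away.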